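The source may hold more compounds than are shown below. What is called first, only, known or untested is meant among the compounds shown, and "the series" means these compounds.

Working notes on the series.

Three compounds carry a measurement in a functional assay on HCC 2998 cells (Homo sapiens) for cytotoxicity, read by sulforhodamine B assay, with a stated time of 48 h; a lower number here means that less compound is tolerated, a higher number that more compound is tolerated. Compound 1 `Nc1nc(Cl)c2ncn(Cc3ccc(CCl)cc3)c2n1` gives 75900 nM. Compound 2 `ClCc1cccc(Cn2cnc3c(Cl)nc(Cl)nc32)c1` gives 6160 nM. Compound 3 `ClCc1ccc(Cn2cnc3c(Cl)nc(Cl)nc32)cc1` gives 56200 nM. Of the three, compound 2 stands lowest, and its gaps to compound 3 and to compound 1 are each beyond the scatter; the difference between the cores of compound 2 and compound 3 is not broken down here, since the two share the same atoms joined differently.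

One structural change is measured within the set: from compound 3 to compound 1, (amino in place of chloro on an aromatic carbon). In this assay the step is a 1.4-fold higher number from compound 3 to compound 1 (0.13 log units; within the scatter), which sits within the scatter, so the change left the tolerated concentration essentially unchanged between those two compounds.

Compound 4 `Nc1nc(Cl)c2ncn(Cc3cccc(CCl)c3)c2n1` has not yet been measured. It relates to compound 2 by the same change, (amino in place of chloro on an aromatic carbon), with the place described in the same words as for the pair of compound 3 and compound 1. For the measured compounds named here, only that single measured pair supports any expectation, so the expectation rests on the step from compound 3 to compound 1 alone.

Because a 1.4-fold higher number from compound 3 to compound 1 (0.13 log units; within the scatter) was small, the step from compound 2 to compound 4 is expected to be of similar size, a 1.4-fold higher number from compound 2 to compound 4 (0.14 log units; within the scatter). Compound 4 is thus estimated at 8600 nM in this assay, with a likely range from 3000 nM to 25000 nM.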

Compound 4, concentration lethal to 50% of the cells: 77600 nM
The estimate for compound 4 lay 9.0-fold (0.96 log units) below the measured number, outside the stated range (above it).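

Amino in place of chloro on an aromatic carbon does not carry over unchanged between the two cores in this assay; the new step is a 13-fold higher number from compound 2 to compound 4 (1.10 log units; beyond the scatter), and set beside the earlier step it differs: the same change on two cores in this assay, a 1.4-fold higher number (0.13 log units; within the scatter) from compound 3 to compound 1 and a 13-fold higher number (1.10 log units; beyond the scatter) from compound 2 to compound 4, 9.3-fold (0.97 log units) apart, beyond the scatter of two such steps. For these two cores, then, the size of the step depends on the core, and a step read on the core of compound 3 gives no safe estimate on the core of compound 2. Two pairs set no rule for any other core and do not show why the steps part; the printed values simply place compound 1 at 75900 nM and compound 4 at 77600 nM, so the difference in step size traces to the low value of compound 2, the chloro member of its pair, at 6160 nM.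

Left open is how other groups at that aromatic carbon, such as methoxy or dimethylamino, would behave on each core, and whether the gap between the steps survives if the chloromethyl group gives way to methyl or hydroxymethyl. From the compounds shown here alone, whether the two cores part in the same way in another cell-based read-out also stays open.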